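The source may hold more compounds than are shown below. What is called first, only, known or untested is meant among the compounds shown, and "the series" means these compounds.

Values in a functional assay on WM164 cells (Homo sapiens) for antiproliferative activity, read by sulforhodamine B assay, with a stated time of 48 h; on this read-out higher numbers stand for weaker inhibition and lower numbers for stronger inhibition:
- compound 1 `CCCCCCCCCCNC(=O)[C@@H]1CSC(c2cc(OC)c(OC)c(OC)c2)N1`: 2100 nM
- compound 2 `CCCCCCCCCCCCCCNC(=O)[C@@H]1CSC(c2cc(OC)c(OC)c(OC)c2)N1`: 1600 nM
- compound 3 `CCCCCCCCCCCCCCCCNC(=O)[C@@H]1CSC(c2ccc(OC)c(OC)c2)N1`: 500 nM

Compound 3 at 500 nM holds the lowest of the three numbers, and the numbers of compound 1 and compound 2 both lie beyond the scatter from it. Compound 4 `CCCCCCCCCCCCCCCCNC(=O)[C@@H]1CSC(c2ccc(NC(C)=O)cc2)N1` carries 4-acetamidophenyl in place of 3,4-dimethoxyphenyl on a saturated ring carbon. Among the compounds with values here, the only measured single-place step, a 1.3-fold lower number from compound 1 to compound 2 (0.12 log units; within the scatter), lies within the scatter and leaves the aryl group untouched, so no measured step covers this change directly. No step beyond the scatter is therefore expected in this assay, with a slight lean towards a higher number. The expected step is a 1.4-fold higher number from compound 3 to compound 4 (0.15 log units; within the scatter). For compound 4 the estimated value is 700 nM, with an expected range from 250 nM to 2000 nM.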

Compound 4, half-maximal inhibitory concentration: 600 nM
Compound 4: the middle estimate sits 1.2-fold (0.07 log units) above what was measured; the measured number falls inside the stated range.
By their numbers in this assay, from the lowest: compounds 3 and 4 (each within the scatter of the next); then compounds 2 and 1 (each within the scatter of the next).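

Within the data shown here, at this saturated ring carbon, 4-acetamidophenyl in place of 3,4-dimethoxyphenyl gives a 1.2-fold higher number from compound 3 to compound 4 (0.08 log units; within the scatter) in this assay, the first measured step at this position. The two groups differ in their hydrogen-bond donors and acceptors, yet their numbers stay within the scatter of each other. Nothing measured here accounts for this result. Open, on these data alone, is whether an amine or a carboxylic acid on the phenyl ring would also stay within the scatter. Also open, as far as these compounds go, is whether 4-acetamidophenyl would behave the same with a shorter chain on the amide.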